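Cytotoxicity series: diarylamine to biaryl at the para position

The compounds below may be only part of what the source reports. "The series", "measured", "known", "first", "only" and "open" are said of these compounds alone.

Compound 1 `C=C[C@@](C)(/C=C/c1ccc(Nc2cc(F)cc(F)c2)cc1)CCC=C(C)C` is the reference. In a functional assay on SEM cells (Homo sapiens) for cytotoxicity, with a stated time of 72 h (on this read-out higher numbers stand for an effect only at larger amounts of compound and lower numbers for an effect already at smaller amounts), compound 1 reaches only the assay limit, > 36600 nM. Compound 2 `C=C[C@@](C)(/C=C/c1ccc(Nc2cc(F)c(F)c(F)c2)cc1)CCC=C(C)C` also stops at a limit in this assay, > 36600 nM. Compound 3 `C=C[C@@](C)(/C=C/c1ccc(Nc2c(F)cc(F)cc2F)cc1)CCC=C(C)C` sits at a limit as well, > 36600 nM. All three therefore rest on the same line, (the limit of > 36600 nM in this assay, at which 3 of the 3 values shown sit), and the steps between them are not readable: a step that the two limits leave unreadable from compound 1 to compound 2; a step that the two limits leave unreadable from compound 1 to compound 3; a step that the two limits leave unreadable from compound 2 to compound 3.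

Compound 4 `C=C[C@@](C)(/C=C/c1ccc(-c2cccc(Br)c2)cc1)CCC=C(C)C` differs from compound 1 as follows: 3-bromophenyl in place of (3,5-difluorophenyl)amino on an aromatic carbon. Within the data shown here, no measured step changes the group at this position, so nothing here sizes the move; the expected step is an at least 1.2-fold lower number from compound 1 to compound 4 (0.08 log units; that floor lies within the scatter), with a high chance of a further limit. Compound 4 is estimated at 30000 nM, within 8000 nM to 100000 nM.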

Compound 4, half-maximal effective concentration: > 36600 nM
Compound 4: a limit, no number; the forecaster's own chance of this, stated with the estimate: 60%; at least 1.2-fold (0.08 log units) between middle value and limit.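

The step from compound 1 to compound 4 cannot be read, since both values are limits: the limit of > 36600 nM in this assay, at which 4 of the 4 values shown sit. The compounds shown leave open whether any change at this position gives a measurable value in this assay.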